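The source may hold more compounds than are shown below. What is called first, only, known or untested is meant among the compounds shown, and "the series" means these compounds.

Compound 1 `CCOC(=O)c1c(-c2ccccc2)oc2ccc(OCCCCN3C(=O)/C(=N\OC)c4cc(F)ccc43)cc12` and compound 2 `CCOC(=O)c1c(-c2ccc(OC)cc2)oc2ccc(OCCCCN3C(=O)/C(=N\OC)c4cc(F)ccc43)cc12` share one core and differ only in that compound 2 carries methoxy in place of hydrogen on an aromatic carbon. In an ADME assay on Vero cells (Chlorocebus sabaeus) for cytotoxicity, read by MTT assay, with a stated time of 72 h (on this read-out higher numbers stand for lower toxicity in this test and lower numbers for higher toxicity in this test), compound 1 gives 64 ug/mL, and compound 2 gives 32 ug/mL, so that the step is a 2.0-fold lower number from compound 1 to compound 2 (0.30 log units; within the scatter). Compound 3 `CCOC(=O)c1c(-c2ccccc2)oc2ccc(OCCCN3C(=O)/C(=N\OC)c4cc(OC)ccc43)cc12` rests on a different core; how its core differs from that of compound 1 is not broken down here. In this assay compound 3 gives 64 ug/mL. Compound 4 `CCOC(=O)c1c(-c2ccc(OC)cc2)oc2ccc(OCCCN3C(=O)/C(=N\OC)c4cc(OC)ccc43)cc12` is built from compound 3 by the same change, (methoxy in place of hydrogen on an aromatic carbon), as carried compound 1 to compound 2. Because the earlier step was a 2.0-fold lower number from compound 1 to compound 2 (0.30 log units; within the scatter), the step to compound 4 is expected to be a 2.0-fold lower number from compound 3 to compound 4 (0.30 log units; within the scatter). Compound 4 is therefore estimated at 32 ug/mL, with a range expected from 16 ug/mL to 64 ug/mL.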

Compound 4, half-maximal cytotoxic concentration: 128 ug/mL
For compound 4 the middle estimate is 4.0-fold (0.60 log units) below the measured one; measured number above the stated range.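

In this assay, the change from phenyl to 4-methoxyphenyl gives a 2.0-fold higher number from compound 3 to compound 4 (0.30 log units; within the scatter), and the effect of this change does not carry over in direction from one core to the other: the same change on two cores in this assay, a 2.0-fold lower number (0.30 log units; within the scatter) from compound 1 to compound 2 and a 2.0-fold higher number (0.30 log units; within the scatter) from compound 3 to compound 4, 4.0-fold (0.60 log units) apart, beyond the scatter of two such steps. Each step alone lies within the scatter, so neither shows by itself that the methoxy group moves the read-out; only the gap between the two steps lies beyond it. Two cores cannot show which part of their difference goes with that gap, and they give no rule for a third core.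

The compounds shown leave open how an amine or a carboxylic acid would behave in place of the methoxy group. They also leave open whether the gap persists on a core with a longer chain.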